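Swapping the Amine Side Chain of Compound 3

The source may report more compounds than this note shows. Statements on the series, on what has been measured and on what is new or still open speak of the compounds shown alone.

In a functional assay on LNCaP cells (Homo sapiens) for antiproliferative activity, read by WST assay, with a stated time of 3 days (on this read-out higher numbers stand for weaker inhibition and lower numbers for stronger inhibition), compound 1 `CCCOc1c(-c2cc(OC)c(OC)c(OC)c2)oc2ccccc2c1=O` gives 5700 nM. Compound 2 `CCN(CC)CCCOc1c(-c2cc(OC)c(OC)c(OC)c2)oc2ccccc2c1=O`, with diethylamino added to the chain, gives 37600 nM, which is a 6.6-fold higher number from compound 1 to compound 2 (0.82 log units; beyond the scatter). Compound 3 `CCN(CC)CCCCOc1c(-c2cc(OC)c(OC)c(OC)c2)oc2ccccc2c1=O`, with (diethylamino)methyl there instead, gives 13500 nM, the middle of the three numbers. That is a 2.4-fold higher number from compound 1 to compound 3 (0.37 log units; beyond the scatter) and a 2.8-fold lower number from compound 2 to compound 3 (0.44 log units; beyond the scatter).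

Compound 4 `CCCN(CCC)CCCOc1c(-c2cc(OC)c(OC)c(OC)c2)oc2ccccc2c1=O` has dipropylamino in place of (diethylamino)methyl, on a saturated chain carbon, three bonds along the chain from an oxygen on an aromatic ring: dipropylamino in place of (diethylamino)methyl on a saturated chain carbon, three bonds along the chain from an oxygen on an aromatic ring. Within the data shown here, no measured step makes this exact swap, so the nearest guide is the pair of modest steps from compound 1 and compound 2 to compound 3. Among the measured compounds shown here, both changed the group at this same place, and the one from compound 2 was a 2.8-fold lower number from compound 2 to compound 3 (0.44 log units; beyond the scatter). The estimate is a 1.2-fold higher number from compound 3 to compound 4 (0.07 log units; within the scatter), which means no expected step beyond the scatter in this assay. Compound 4 is expected at 16000 nM, with an estimated range of 6000 nM to 40000 nM.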

Compound 4, half-maximal inhibitory concentration: 17900 nM
Compound 4: the middle estimate sits 1.1-fold (0.05 log units) below what was measured; measured number inside the range.
By their numbers in this assay, from the lowest: compound 1; then compounds 3 and 4 (each within the scatter of the next); then compound 2.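

In this assay, among these compounds, dipropylamino in place of diethylamino at this place gives a 2.1-fold lower number from compound 2 to compound 4 (0.32 log units; beyond the scatter), so changing only the groups on the nitrogen is enough to move the number beyond the scatter, which the earlier steps could not show. Dipropylamino in place of (diethylamino)methyl gives a 1.3-fold higher number from compound 3 to compound 4 (0.12 log units; within the scatter), so these two different changes to the amine end of the side chain lead to numbers within the scatter of each other. The step from the plain chain, a 3.1-fold higher number from compound 1 to compound 4 (0.50 log units; beyond the scatter), shows that compound 4 joins compound 2 and compound 3 in standing at a higher number than compound 1.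

Nothing available gives a reason for these differences. The compounds shown leave open how a ring amine such as piperidine or morpholine, or a smaller dimethylamino group, would read at this place.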